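A few compounds are considered here, and "the series" means these few. Any claim that something is new, unique, unknown or untested is made for them only; others in the source may bear on it.

Compound 1 `COc1ccc(C2SCC(=O)N2CCN2CCCCC2)cc1` was tested in an ADME assay on Vero cells (Chlorocebus sabaeus) for cytotoxicity, read by neutral red uptake, tested at 49 ug/mL (on this read-out higher numbers stand for a weaker effect at the one concentration tested and lower numbers for a stronger effect), where compound 1 gives 100%. Two close relatives give the same picture: compound 2 `O=C1CSC(c2cccc(O)c2)N1CCN1CCCCC1` gives 100%, and compound 3 `Cc1ccc(C2SCC(=O)N2CCN2CCCCC2)cc1` gives 100%. The step from compound 1 to compound 3 is no change at the digits printed from compound 1 to compound 3 (within the scatter), and the step from compound 2 to compound 3 is no change at the digits printed from compound 2 to compound 3 (within the scatter). Compound 1 thus stands level with compounds 2 and 3, and none of the three shows any effect at the concentration tested.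

Compound 4 `O=C1CSC(c2ccc(F)cc2)N1CCN1CCCCC1` differs from compound 1 as follows: fluoro in place of methoxy on an aromatic carbon. For the measured compounds named here, the only steps that bear on this are the two above, each a swap of a small group on the aromatic ring of the shared core, and neither moved the read-out. Since every change seen so far left this assay unchanged, no step beyond the scatter is expected here, and compound 4 is expected to give 100%, between 88% and 100%, an expected step of no change at the digits printed from compound 1 to compound 4 (within the scatter).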

Compound 4, a percentage reported as activity, at one concentration (the size of the read-out at that concentration, not a potency): 100%
Beside the measured number, compound 4's estimate shows no gap at the digits printed; measured number inside the range.
By their numbers in this assay, from the lowest: compounds 1, 2, 3 and 4 (each within the scatter of the next).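

In this assay the fluoro group fits the earlier picture: the read-out gives no change at the digits printed from compound 1 to compound 4 (within the scatter) and no change at the digits printed from compound 3 to compound 4 (within the scatter) and no change at the digits printed from compound 2 to compound 4 (within the scatter) as well. What is new is the kind of group at this place, on an aromatic carbon para to a large group: fluoro brings one fluorine atom and no hydrogen-bond acceptor, whereas methoxy has two heavy atoms and one acceptor, yet the read-out stays level. No measurement here offers an explanation for this flat result.

On these data alone, whether an amine, a carboxylic acid or a longer chain at this place would also leave the read-out level remains open. All the compounds shown share the rest of the core, so the effect of changing that part in this assay is open too.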